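The compounds below may be only part of what the source reports. "The series", "measured", "known", "first", "only" and "open" are said of these compounds alone.

Measured so far:
- Compound 1 `O=C(O)CCC(=O)OCCCCCCSc1ccc([N+](=O)[O-])c2nonc12`: 1890 nM
- Compound 2 `COc1ccccc1NC(=O)CCC(=O)OCCCCCCSc1ccc([N+](=O)[O-])c2nonc12`: 4490 nM

In an ADME assay on L02 cells (Homo sapiens) for cytotoxicity, read by MTT assay, with a stated time of 72 h (a lower number here means a stronger inhibitor, a higher number a weaker inhibitor), compound 2 has the higher of the two numbers, at 4490 nM. Compound 3 `O=C(CCC(=O)OCCCCCCSc1ccc([N+](=O)[O-])c2nonc12)Nc1ccc(F)cc1` differs from it on an amide-type nitrogen: 4-fluorophenyl in place of 2-methoxyphenyl on an amide-type nitrogen. Within the data shown here, the one measured step, a 2.4-fold higher number from compound 1 to compound 2 (0.38 log units; beyond the scatter), was modest and put (2-methoxyphenyl)amino in place of hydroxy on a carbonyl carbon. It does not test a swap of one ring group for another, so no step beyond the scatter is expected in this assay. The expected change is a 1.1-fold lower number from compound 2 to compound 3 (0.05 log units; within the scatter). For compound 3 the estimated value is 4000 nM, with an expected range of 1800 nM to 9000 nM.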

Compound 3, half-maximal inhibitory concentration: 6460 nM
Compound 3: middle estimate off by 1.6-fold (0.21 log units), on the low side, and the stated range covers the measured number.
By their numbers in this assay, from the lowest: compound 1; then compounds 2 and 3 (each within the scatter of the next).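

In this assay, exchanging 2-methoxyphenyl for 4-fluorophenyl on the amide-type nitrogen gives a 1.4-fold higher number from compound 2 to compound 3 (0.16 log units; within the scatter), so the two rings cannot be told apart here. Against the acid, the second amide also stands apart, with a 3.4-fold higher number from compound 1 to compound 3 (0.53 log units; beyond the scatter); compounds 2 and 3 therefore both read beyond the scatter from compound 1, which suggests that this holds for more than one ring. Nothing available explains these numbers.

Going by these compounds, what a benzyl group or a simple methyl group on this nitrogen would give remains open. So does whether an amide without any ring would also separate from compound 1.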